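Aryl ring changes on the shared core: compound 4

The compounds below may be only part of what the source reports. "The series", "measured", "known", "first", "only" and "open" are said of these compounds alone.

Compound 3 `CCCCCc1c(C(C)C)nc(C(C)C)c(CO)c1-c1cccc(OC)c1` gives 48000 nM in an assay on CHO cells for inhibition of Glucagon receptor (Homo sapiens) (a higher number here means a weaker inhibitor, a lower number a stronger inhibitor), the highest number among the three measured compounds. Compound 1 `CCCCCc1c(C(C)C)nc(C(C)C)c(CO)c1-c1ccc(C)cc1` gives 1000 nM and compound 2 `CCCCCc1c(C(C)C)nc(C(C)C)c(CO)c1-c1cccc(O)c1` gives 6000 nM; the measured steps are a 48-fold higher number from compound 1 to compound 3 (1.68 log units; beyond the scatter), a 6.0-fold higher number from compound 1 to compound 2 (0.78 log units; beyond the scatter) and an 8.0-fold higher number from compound 2 to compound 3 (0.90 log units; beyond the scatter). Compound 4 `CCCCCc1c(C(C)C)nc(C(C)C)c(CO)c1-c1ccccc1N` carries 2-aminophenyl in place of 3-methoxyphenyl on an aromatic carbon. Within the data shown here, none of the measured steps introduces an amino group, so the only guide is an 8.0-fold higher number from compound 2 to compound 3 (0.90 log units; beyond the scatter), which shows that losing the methyl from the methoxy group lowers the number in this assay. Since compound 4 also loses that group, a downward step of about a 6.0-fold lower number from compound 3 to compound 4 (0.78 log units; beyond the scatter) is expected, with wide uncertainty. Compound 4 is estimated at 8000 nM, within a range of 1500 nM to 40000 nM.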

Compound 4, half-maximal inhibitory concentration: 2300 nM
The estimate for compound 4 lay 3.5-fold (0.54 log units) above the measured number; measured number inside the range.
By their numbers in this assay, from the lowest: compound 1; then compound 4; then compound 2; then compound 3.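

At this aromatic carbon of the shared core, in this assay, 2-aminophenyl gives a much lower number than 3-methoxyphenyl (a 21-fold lower number from compound 3 to compound 4 (1.32 log units; beyond the scatter)) and a modestly lower one than 3-hydroxyphenyl (a 2.6-fold lower number from compound 2 to compound 4 (0.42 log units; beyond the scatter)). It does not match 4-methylphenyl (a 2.3-fold higher number from compound 1 to compound 4 (0.36 log units; beyond the scatter)), which keeps the lowest number of the four.

In these steps, the substituent and its place on the aryl ring change together, so the aryl groups 3-aminophenyl and 2-methoxyphenyl would be needed to separate the two. No measurement at hand explains the differences among these aryl groups.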